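Working notes: amide replacements on the shared core

A few compounds are considered here, and "the series" means these few. Any claim that something is new, unique, unknown or untested is made for them only; others in the source may bear on it.

Compound 2 `Cc1cc(C(=O)NC2CC2)nn1Cc1cc(Cl)cc2cc(-c3ccccc3)oc12` carries a cyclopropylcarbamoyl group on the five-membered aromatic ring of the shared core. In an assay on CHO-K1 cells for displacement of a labelled ligand from prostaglandin E2 receptor EP1 subtype (Homo sapiens), read by scintillation counting, with a stated time of 45 min (on this read-out higher numbers stand for weaker inhibition and lower numbers for stronger inhibition), compound 2 gives 5.01 nM. Compound 1 `Cc1cc(C(=O)NN2CCOCC2)nn1Cc1cc(Cl)cc2cc(-c3ccccc3)oc12` differs only on the amide-type nitrogen, where morpholin-4-yl stands in place of cyclopropyl; in this assay compound 1 gives 10 nM. Among the measured compounds shown here, the single measured step, a 2.0-fold lower number from compound 1 to compound 2 (0.30 log units; within the scatter), is within the scatter, so compound 2 holds the lowest of the two numbers without that gap counting as a real difference.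

Compound 3 `Cc1cc(NC(=O)C2(F)CCNCC2)nn1Cc1cc(Cl)cc2cc(-c3ccccc3)oc12` is the next member: ((4-fluoropiperidin-4-yl)carbonyl)amino in place of cyclopropylcarbamoyl on an aromatic carbon. This replaces the whole carboxamide unit rather than only its nitrogen substituent, so the step from compound 1 to compound 2 bears on it only loosely: it shows that exchanging one substituent on the amide-type nitrogen for another left this assay essentially unchanged, but says nothing about reversing the amide or bringing in the 4-fluoropiperidin-4-yl ring. For the measured compounds named here, no measured step covers that. The expected outcome is therefore a modest weakening with wide uncertainty, a 6.0-fold higher number from compound 2 to compound 3 (0.78 log units; beyond the scatter) being the estimated step. Compound 3 is expected to give 30 nM in this assay, within a range from 5 nM to 200 nM.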

Compound 3, half-maximal inhibitory concentration: 39.8 nM
The estimate for compound 3 lay 1.3-fold (0.12 log units) below the measured number; measured number inside the range.
By their numbers in this assay, from the lowest: compounds 2 and 1 (each within the scatter of the next); then compound 3.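

In this assay, the change at this aromatic carbon registers where the earlier exchange on the amide-type nitrogen did not: the step is a 7.9-fold higher number from compound 2 to compound 3 (0.90 log units; beyond the scatter), and against the other amide it is a 4.0-fold higher number from compound 1 to compound 3 (0.60 log units; beyond the scatter). Both steps lie beyond the scatter, so this position responds to replacing the whole carboxamide unit, although the size of the step is modest and compound 3 still gives a measurable 39.8 nM with ((4-fluoropiperidin-4-yl)carbonyl)amino in place. No measurement available here accounts for the higher number.

The change alters several things at once, namely the direction of the amide, the ring and the fluorine, so these steps cannot assign the shift to any one of them. Still open, as far as these compounds go, is whether cyclopropylcarbonylamino on the same aromatic carbon would separate the amide direction from the ring, and whether a piperidin-4-ylcarbonylamino group, with hydrogen in place of the fluorine, would give a number different from that of compound 3.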